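The source may report more compounds than this note shows. Statements on the series, on what has been measured and on what is new or still open speak of the compounds shown alone.

Working notes on the series.

Three analogues sharing one core differ only in the aryl group on the saturated chain carbon bound to an aromatic carbon and a nitrogen on an aromatic ring. In an assay for inhibition of protein disulfide-isomerase (Homo sapiens), with a stated time of 1 h (on this read-out higher numbers stand for weaker inhibition and lower numbers for stronger inhibition), compound 1 `Oc1c(C(Nc2ccccn2)c2ccccc2Cl)ccc2cccnc12` gives 500 nM. In this assay compound 2 `COc1cccc(C(Nc2ccccn2)c2ccc3cccnc3c2O)c1` gives 2860 nM. In this assay compound 3 `Cc1ccc(C(Nc2ccccn2)c2ccc3cccnc3c2O)cc1` gives 460 nM, the lowest number of the three; its nearest neighbour is compound 1, with a 1.1-fold lower number from compound 1 to compound 3 (0.04 log units; within the scatter), and its furthest is compound 2, with a 6.2-fold lower number from compound 2 to compound 3 (0.79 log units; beyond the scatter). The remaining step, a 5.7-fold higher number from compound 1 to compound 2 (0.76 log units; beyond the scatter), shows that the 3-methoxyphenyl compound stands apart, whereas the 2-chlorophenyl and 4-methylphenyl compounds cannot be told apart.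

Compound 4 `Cc1cc(C)c(C(Nc2ccccn2)c2ccc3cccnc3c2O)c(C)c1` is not yet measured. Its change from compound 3 is 2,4,6-trimethylphenyl in place of 4-methylphenyl on a saturated chain carbon bound to an aromatic carbon and a nitrogen on an aromatic ring. Among the compounds with values here, no measured step adds methyl groups to an aryl that already carries one; the only steps that bear on it are the swaps of whole aryl groups, of which a 1.1-fold lower number from compound 1 to compound 3 (0.04 log units; within the scatter) was within scatter and a 6.2-fold lower number from compound 2 to compound 3 (0.79 log units; beyond the scatter) and a 5.7-fold higher number from compound 1 to compound 2 (0.76 log units; beyond the scatter) were modest. Swapping one aryl for another has so far moved this assay by at most a modest step, so a step of similar size or smaller is expected here, with no firm direction. Compound 4 is therefore estimated at 700 nM, with a range from 250 nM to 2500 nM. This estimate means an expected step of a 1.5-fold higher number from compound 3 to compound 4 (0.18 log units; within the scatter).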

Compound 4, half-maximal inhibitory concentration: 190 nM
The estimate for compound 4 lay 3.7-fold (0.57 log units) above the measured number; measured number below the stated range.
By their numbers in this assay, from the lowest: compound 4; then compounds 3 and 1 (each within the scatter of the next); then compound 2.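

In this assay, within the data shown here, 2,4,6-trimethylphenyl is the first aryl group at this place to separate from both 4-methylphenyl (a 2.4-fold lower number from compound 3 to compound 4 (0.38 log units; beyond the scatter)) and 2-chlorophenyl (a 2.6-fold lower number from compound 1 to compound 4 (0.42 log units; beyond the scatter)), two groups that could not be told apart in the earlier compounds. Among these compounds, it also gives the first large step (a 15-fold lower number from compound 2 to compound 4 (1.18 log units; beyond the scatter)), so swapping one aryl for another on this saturated chain carbon can move the number by more than the modest steps seen before, and adding two methyl groups to the 4-methylphenyl group lowered it rather than leaving it within the scatter. No measured property in hand bears on why this change lowers the number.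

The compounds shown leave open whether a single added methyl group, as in a dimethylphenyl group, would account for part of this step or whether all three methyl groups are needed. They also leave open how unsubstituted phenyl, a larger alkyl group such as tert-butyl on the aryl ring, or a phenyl ring carrying an amine or a carboxylic acid would read in this assay.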